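Moving a Chloro Group on a Shared Core

The compounds below may be only part of what the source reports. "The series", "measured", "known", "first", "only" and "open" are said of these compounds alone.

Measured compounds:
- compound 1, `COc1cc2c(/C=C3/C(=O)Nc4ccc(O)cc43)c(Cl)n(Cc3cc(OC)c(OC)c(OC)c3)c2cc1C`, 2340 nM
- compound 2, `COc1cc2c(/C=C3/C(=O)Nc4ccc(Cl)cc43)c(Cl)n(Cc3cc(OC)c(OC)c(OC)c3)c2cc1C`, 3720 nM
- compound 3, `O=C1/C(=C/c2c(Cl)[nH]c3ccccc23)c2ccccc2N1Cc1ccccc1`, 9120 nM

In a functional assay on cells (Cancer cell lines, Homo sapiens) for cytotoxicity, with a stated time of 48 h (on this read-out lower numbers stand for stronger inhibition of growth and higher numbers for weaker inhibition of growth), compound 2 gives 3720 nM, which places it second highest of the three numbers. Its nearest neighbour is compound 1, and the step of a 1.6-fold higher number from compound 1 to compound 2 (0.20 log units; within the scatter) lies within the scatter. Among the compounds with values here, compound 3 gives 9120 nM, a higher number than compound 2 and beyond the scatter, but compound 3 differs from compound 2 in several places at once, so no single step can be drawn from it.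

Compound 4, `COc1cc2c(/C=C3/C(=O)Nc4cccc(Cl)c43)c(Cl)n(Cc3cc(OC)c(OC)c(OC)c3)c2cc1C`, is not yet measured. It keeps every atom of compound 2 but joins them differently: a group of 12 heavy atoms (9 carbon, 1 nitrogen, 1 oxygen, 1 chlorine; one five-membered non-aromatic ring with 1 hetero atom, one six-membered aromatic ring of carbon only) in place of a group of 12 heavy atoms (9 carbon, 1 nitrogen, 1 oxygen, 1 chlorine; one five-membered non-aromatic ring with 1 hetero atom, one six-membered aromatic ring of carbon only), on an aromatic carbon. Within the data shown here, the only single-point step measured so far, the exchange of hydroxy for chloro on the same ring from compound 1 to compound 2, did not move the number beyond the scatter, and no measured pair tests a shift of the chloro group itself. The expected step is therefore none beyond the scatter, a 1.1-fold lower number from compound 2 to compound 4 (0.03 log units; within the scatter). Compound 4 is estimated at 3500 nM, with a range from 1500 nM to 9000 nM in this assay.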

Compound 4, concentration for 50% growth inhibition: 3980 nM
Estimate against measurement, compound 4: 1.1-fold (0.06 log units) below, within the range that was stated.
By their numbers in this assay, from the lowest: compounds 1, 2 and 4 (each within the scatter of the next); then compound 3.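

In this assay the chloro group can sit on a different carbon of the six-membered aromatic ring without a step beyond the scatter, with a 1.1-fold higher number from compound 2 to compound 4 (0.03 log units; within the scatter) as the result. The comparison with the hydroxy compound gives the same picture, with a 1.7-fold higher number from compound 1 to compound 4 (0.23 log units; within the scatter) also inside the scatter, so neither the exchange of hydroxy for chloro nor the shift of chloro has yet moved the number clearly on this ring. No other measurement at hand bears on this result.

The compounds shown leave open whether an amine or a carboxylic acid on this ring would give a step beyond the scatter. They also leave open whether a hydroxy group on the carbon that bears chloro in compound 4 would stay within the scatter of compound 1.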